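The source may report more compounds than this note shows. Statements on the series, on what has been measured and on what is new or still open speak of the compounds shown alone.

Compound 3 `Cc1ccc(C(=O)O)cc1OCCCCOc1ccc(C(=O)CC2CCCC2)c(O)c1C` stands at the edge of what the measurements show: in an assay on HEK293 cells for positive allosteric modulation of metabotropic glutamate receptor 3 (Rattus norvegicus), read by thallium flux, with a stated time of 2.5 min (on this read-out lower numbers stand for an effect already at smaller amounts and higher numbers for an effect only at larger amounts of compound), compound 3 gives > 10000 nM, a limit of the assay and not a number. Compound 1 `Cc1c(OCCCCOCOc2ccc(C(=O)O)cc2)ccc(C(=O)CC2CCCC2)c1O` gives 1910 nM in this assay. Compound 2 `Cc1c(OCCCCOc2ccccc2C(=O)O)ccc(C(=O)CC2CCCC2)c1O` gives "not determined" (no result reported) in this assay. Among the compounds with values here, the one measured step, an at least 5.2-fold higher number from compound 1 to compound 3 (0.71 log units; beyond the scatter), runs into (the limit of > 10000 nM in this assay, at which 1 of the 3 values shown sits). Compound 4 `Cc1c(OCCCCOc2ccc(C(=O)O)c(Cl)c2)ccc(C(=O)CC2CCCC2)c1O` differs from compound 3 by 4-carboxy-3-chlorophenyl in place of 5-carboxy-2-methylphenyl on an oxygen on a saturated carbon. Within the data shown here, no measured step follows this exact exchange, so the expectation rests on compound 1 and compound 3 alone, with the step between them as the only pointer. The account therefore expects a step of an at least 2.8-fold lower number from compound 3 to compound 4 (0.45 log units; beyond the scatter) for compound 4, downward from the limit. Compound 4 is estimated at 3500 nM in this assay, within 900 nM to 12000 nM.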

Compound 4, half-maximal effective concentration: 2250 nM
Compound 4: middle estimate off by 1.6-fold (0.19 log units), on the high side; measured number inside the range.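

In this assay, 4-carboxy-3-chlorophenyl in place of 5-carboxy-2-methylphenyl on this oxygen restores a measurable value, with an at least 4.4-fold lower number from compound 3 to compound 4 (0.64 log units; beyond the scatter). Compound 3 gives a limit and not a number, so this step is only a bound: the limit of > 10000 nM in this assay, at which 1 of the 4 values shown sits. Set against (4-carboxyphenoxy)methyl, the new group gives a 1.2-fold higher number from compound 1 to compound 4 (0.07 log units; within the scatter), so the two groups cannot be told apart here. The exchange swaps a methyl for a chlorine and also moves the carboxylic acid, and the compounds shown do not separate these two changes. Going by these compounds, whether a fluorine or a nitrile could stand in for the chlorine also remains open.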